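This account rests on a few compounds, and the source may have more. Where it says the series, first, only, none or still open, it means among the compounds named here.

Measured so far in a functional assay on SMMC-7721 cells (Homo sapiens) for inhibition, read by MTT assay, with a stated time of 72 h, tested at 1 uM; on this read-out lower numbers stand for a weaker effect and higher numbers for a stronger effect at the one concentration tested:
compound 1 `Clc1ccc(COc2ccccc2/C=C/C(/C=C/c2ccccn2)=N/Oc2ncnc3cc(Cl)ccc23)c(Cl)c1` gives 23.6%
compound 2 `Clc1ccccc1COc1ccccc1/C=C/C(/C=C/c1ccccn1)=N/Oc1ncnc2ccccc12` gives 95.7%
compound 3 `Cc1cccc2ncnc(O/N=C(\C=C\c3ccccn3)/C=C/c3ccccc3OCc3ccccc3Cl)c12` gives 86.8%

Compound 3 stands second highest of these three numbers. The nearest step is a number 8.9 percentage points lower from compound 2 to compound 3 (within the scatter), which stays within the scatter, while compound 1 lies far below compound 3, beyond the scatter. Compound 4 `Cc1cccc2ncnc(O/N=C(\C=C\c3ccccn3)/C=C/c3ccccc3OCc3ccc(Cl)cc3Cl)c12` differs from compound 3 by chloro in place of hydrogen on an aromatic carbon. For the measured compounds named here, no measured one-place step shares this change, since the only such step concerns a methyl group on the shared core. Compound 1 also carries the 2,4-dichlorobenzyl group and is the weakest here, but it differs from compound 2 in two places, so its low number cannot be laid to that group alone. A drop is therefore possible but uncertain. Compound 4 is expected to give 60%, with a range from 20% to 95%, which means an estimated step of a number 26.8 percentage points lower from compound 3 to compound 4 (beyond the scatter).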

Compound 4, a percentage reported as inhibition, at one concentration (the size of the read-out at that concentration, not a potency): 90.8%
The estimate for compound 4 lay 30.8 percentage points below the measured number, and the stated range covers the measured number.
By their numbers in this assay, from the lowest: compound 1; then compounds 3, 4 and 2 (each within the scatter of the next).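

In this assay, the change from 2-chlorobenzyl to 2,4-dichlorobenzyl is a number 4 percentage points higher from compound 3 to compound 4 (within the scatter) and so leaves the number unchanged within the scatter, showing that this second chloro is tolerated on the core of compound 3. With 2,4-dichlorobenzyl held fixed, the core change alone is a number 67.2 percentage points higher from compound 1 to compound 4 (beyond the scatter) and shows that this group does not by itself bring a low number. No evidence here explains either step. From the compounds shown here alone, whether a larger group at this place, such as methoxy or an amine, would be tolerated stays open. So does the effect of the 2,4-dichlorobenzyl change on the unsubstituted core of compound 2.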